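Replacing the 2-chloro-6-methylphenyl group of compound 3

The source may report more compounds than this note shows. Statements on the series, on what has been measured and on what is new or still open speak of the compounds shown alone.

In a functional assay on A549 cells (Homo sapiens) for cytotoxicity, read by MTT assay, with a stated time of 72 h (a higher number here means a weaker inhibitor, a lower number a stronger inhibitor), compound 3 (`Cc1cccc(Cl)c1NC(=O)CN1CCN(c2nnc(Cc3ccccc3)c3ccccc23)CC1`) gives 7420 nM as the highest number of the three measured. Compound 4 (`O=C(CN1CCN(c2nnc(Cc3ccccc3)c3ccccc23)CC1)Nc1ccc(F)c(Cl)c1`) carries 3-chloro-4-fluorophenyl in place of 2-chloro-6-methylphenyl on an amide-type nitrogen. The entering group looks most like the 4-fluoro-3-(trifluoromethyl)phenyl of compound 1 (`O=C(CN1CCN(c2nnc(Cc3ccccc3)c3ccccc23)CC1)Nc1ccc(F)c(C(F)(F)F)c1`), which gives 2480 nM and stands apart from compound 3 by a modest step (a 3.0-fold higher number from compound 1 to compound 3 (0.48 log units; beyond the scatter)). Compound 2 (`O=C(CN1CCN(c2nnc(Cc3ccccc3)c3ccccc23)CC1)Nc1ccc(Br)cc1`) gives 2000 nM with a similar step (a 3.7-fold higher number from compound 2 to compound 3 (0.57 log units; beyond the scatter)), and the step separating those two stays within the scatter (a 1.2-fold lower number from compound 1 to compound 2 (0.09 log units; within the scatter)). A lower number of similar modest size is therefore expected (a 2.9-fold lower number from compound 3 to compound 4 (0.46 log units; beyond the scatter)). Compound 4 is estimated at 2600 nM with 1300 nM to 5200 nM as the expected range.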

Compound 4, half-maximal inhibitory concentration: "not active" (no number reported)
Nothing numeric was reported for compound 4; there is nothing to compare the estimate with.
By their numbers in this assay, from the lowest: compounds 2 and 1 (each within the scatter of the next); then compound 3.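

For the compounds shown here, compound 4 was reported as "not active" in this assay with no number, so no step linking it to compound 3 or any other compound can be read. On these data alone, how far the 3-chloro-4-fluorophenyl group separates compound 4 from the others stays open, and no evidence at hand bears on this result.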